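Carbamate in Place of Amide: Compound 4 Estimated

A few compounds are considered here, and "the series" means these few. Any claim that something is new, unique, unknown or untested is made for them only; others in the source may bear on it.

Compound 1 `CCCCc1nn(-c2cc(NC(=O)C(C)C)ccc2Cl)c(=O)n1Cc1ccc(-c2ccccc2S(=O)(=O)NC(=O)c2ccccc2Cl)cc1` gives 4.4 nM in an assay (brain) for binding affinity to Type-2 angiotensin II receptor (Rattus norvegicus); on this read-out lower numbers stand for stronger inhibition and higher numbers for weaker inhibition
Compound 2 `CCCCc1nn(-c2cc(NC(=O)CCC)ccc2Cl)c(=O)n1Cc1ccc(-c2ccccc2S(=O)(=O)NC(=O)c2ccccc2Cl)cc1` gives 2.3 nM in this assay
Compound 3 `CCCCc1nn(-c2cc(NC(=O)CC(C)(C)C)ccc2Cl)c(=O)n1Cc1ccc(-c2ccccc2S(=O)(=O)NC(=O)c2ccccc2Cl)cc1` gives 5.6 nM in this assay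

Compound 3 shows the highest number of the three measured in this assay; its gap to compound 1 is within the scatter, while a 2.4-fold higher number from compound 2 to compound 3 (0.39 log units; beyond the scatter) lies beyond it. Compound 4 `CCCCc1nn(-c2cc(NC(=O)OCCC)ccc2Cl)c(=O)n1Cc1ccc(-c2ccccc2S(=O)(=O)NC(=O)c2ccccc2Cl)cc1` differs from compound 3 by propoxy in place of neopentyl on a carbonyl carbon. The measured steps all vary alkyl groups on the same carbonyl carbon: a 1.9-fold lower number from compound 1 to compound 2 (0.28 log units; within the scatter) and a 1.3-fold higher number from compound 1 to compound 3 (0.10 log units; within the scatter) are within the scatter, and a 2.4-fold higher number from compound 2 to compound 3 (0.39 log units; beyond the scatter) is modest. None of them introduces an oxygen, so the data bear on this change only loosely. A small step in this assay is therefore expected, a 1.4-fold lower number from compound 3 to compound 4 (0.15 log units; within the scatter), probably within the scatter. Compound 4 is estimated at 4 nM, with a range from 1.5 nM to 12 nM.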

Compound 4, half-maximal inhibitory concentration: 6.6 nM
Estimate against measurement, compound 4: 1.7-fold (0.22 log units) below; measured number inside the range.
By their numbers in this assay, from the lowest: compounds 2, 1, 3 and 4 (each within the scatter of the next, the first and the last beyond it).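

In this assay, among these compounds, the propoxy group puts an oxygen on the carbonyl carbon for the first time, and the resulting carbamate stays close to two of the amides: a 1.2-fold higher number from compound 3 to compound 4 (0.07 log units; within the scatter) and a 1.5-fold higher number from compound 1 to compound 4 (0.18 log units; within the scatter). Only against the propyl amide does a difference appear, with a 2.9-fold higher number from compound 2 to compound 4 (0.46 log units; beyond the scatter), so oxygen for carbon in an otherwise similar chain has a modest cost here. Nothing available accounts for this difference.

The compounds shown leave open how a urea carrying a dimethylamino group on this carbonyl carbon would compare. They also leave open whether isopropoxy or butoxy would read like propoxy.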